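Removing the methoxy from the benzyl group of compound 3

The compounds below may be only part of what the source reports. "The series", "measured", "known", "first", "only" and "open" are said of these compounds alone.

The measured compounds and their values:
- compound 1 `COc1cc2c(cc1OC)CN(CCCCNC(=O)c1cn(-c3ccccc3OCCF)nn1)CC2`: 17100 nM
- compound 2 `COc1cc2c(cc1OC)CN(CCCCNC(=O)c1c[nH]nn1)CC2`: 11000 nM
- compound 3 `COc1ccc(Cn2cc(C(=O)NCCCCN3CCc4cc(OC)c(OC)cc4C3)nn2)cc1`: 3350 nM

All three share the same core and differ only in the group carried on an aromatic nitrogen. In an assay on membranes from brain for displacement of a labelled ligand from Sigma non-opioid intracellular receptor 1 (Cavia porcellus), read by scintillation counting, with a stated time of 90 min (on this read-out lower numbers stand for stronger inhibition and higher numbers for weaker inhibition), compound 3 gives the lowest number of the three: the step of a 5.1-fold lower number from compound 1 to compound 3 (0.71 log units; beyond the scatter) and the step of a 3.3-fold lower number from compound 2 to compound 3 (0.52 log units; beyond the scatter) both lie beyond the scatter, while the step of a 1.6-fold lower number from compound 1 to compound 2 (0.19 log units; within the scatter) does not.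

Compound 4 `COc1cc2c(cc1OC)CN(CCCCNC(=O)c1cn(Cc3ccccc3)nn1)CC2` is the next compound. The change from compound 3 to compound 4 is hydrogen in place of methoxy on an aromatic carbon. Going by the values given here, none of the measured steps touches this part of the molecule; they all concern the group on the aromatic nitrogen, so they show only that a 4-methoxybenzyl group on that nitrogen is linked with the lowest number seen so far. As far as these compounds go, whether the methoxy itself carries part of that is unknown. The expectation for compound 4 is therefore a small step, a 1.3-fold higher number from compound 3 to compound 4 (0.13 log units; within the scatter), within the scatter, perhaps toward a slightly higher number. Compound 4 is estimated at 4500 nM, within a range from 1800 nM to 12000 nM.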

Compound 4, inhibition constant: 4480 nM
For compound 4 the middle estimate is 1.0-fold (0.00 log units) above the measured one; the range from low to high includes it.
By their numbers in this assay, from the lowest: compounds 3 and 4 (each within the scatter of the next); then compounds 2 and 1 (each within the scatter of the next).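

In this assay the methoxy on the benzyl group turns out to add nothing that can be told apart from the usual scatter, since hydrogen in its place gives a 1.3-fold higher number from compound 3 to compound 4 (0.13 log units; within the scatter) and the two compounds cannot be ranked. The earlier steps shown here could not separate the methoxy from the rest of the 4-methoxybenzyl group, but the plain benzyl group now shows the same kind of gap from the other nitrogen substituents, with a 2.5-fold lower number from compound 2 to compound 4 (0.39 log units; beyond the scatter) for hydrogen on that nitrogen and a 3.8-fold lower number from compound 1 to compound 4 (0.58 log units; beyond the scatter) for 2-(2-fluoroethoxy)phenyl there, so within these four compounds the benzyl part alone is enough to go with the lower numbers. Nothing given here explains why the methoxy makes no clear difference at this place.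

As far as these compounds go, it remains open whether any other group on this aromatic carbon would behave the same way, for example an amine, a hydroxyl, a chlorine atom or a carboxylic acid. From the compounds shown here alone, it is also open whether the number would move with a methoxy elsewhere on the ring, or with a phenethyl group in place of benzyl on the aromatic nitrogen.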